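Fluoro for hydroxy in a series without measured activity

The compounds below may be only part of what the source reports. "The series", "measured", "known", "first", "only" and "open" are said of these compounds alone.

Measured compounds:
compound 1 `COc1nc(=O)n(C)c(CC(F)(COC(C)=O)COC(C)=O)c1C`: in a functional assay on SW-620 cells (Homo sapiens) for antiproliferative activity, read by MTT assay, with a stated time of 72 h (on this read-out lower numbers stand for stronger inhibition and higher numbers for weaker inhibition), compound 1 gives > 100000 nM, a limit of the assay.
compound 2 `COc1nc(=O)n(C)c(CC(O)(COC(C)=O)COC(C)=O)c1C`: in this assay compound 2 gives > 100000 nM, a limit of the assay.
compound 3 `CC(=O)OCC(O)(COC(C)=O)Cc1c(C)c(=O)[nH]c(=O)n1C`: in this assay compound 3 gives > 100000 nM, a limit of the assay.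

Compound 2 and compound 1 share a core and differ only by fluoro in place of hydroxy on a saturated chain carbon bound to three saturated chain carbons; the step that the two limits leave unreadable from compound 2 to compound 1 cannot be read because both sit at the limit of > 100000 nM in this assay, at which 3 of the 3 values shown sit. The core of compound 3 differs from that of compound 2; the difference between the two cores is not broken down here. Compound 4 `CC(=O)OCC(F)(COC(C)=O)Cc1c(C)c(=O)[nH]c(=O)n1C`, not yet measured, differs from compound 3 by fluoro in place of hydroxy on a saturated chain carbon bound to three saturated chain carbons, the same change. Compound 4 is expected to show a step that the limit leaves unreadable from compound 3 to compound 4, resting on a step that the two limits leave unreadable from compound 2 to compound 1. That expectation also rests on compound 3 sitting at > 100000 nM, a limit of the assay. Compound 4 is therefore estimated at 150000 nM, between 50000 nM and 500000 nM, most likely reported as a limit.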

Compound 4, half-maximal inhibitory concentration: > 100000 nM
Compound 4 was reported as a limit (the forecaster's own chance of this, stated with the estimate: 85%); the middle value is on the limit's open side.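

No step can be read from compound 3 to compound 4, nor from compound 2 to compound 1: the limit of > 100000 nM in this assay, at which 4 of the 4 values shown sit. The compounds shown leave open what fluoro in place of hydroxy does to activity on either core.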